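From Allyl to Ethyl: What to Expect for Compound 3

The compounds below may be only part of what the source reports. "The series", "measured", "known", "first", "only" and "open" are said of these compounds alone.

Measured so far in a functional assay on MCF7 cells (Homo sapiens) for cytotoxicity, read by MTT assay, with a stated time of 72 h; on this read-out lower numbers stand for higher toxicity in this test and higher numbers for lower toxicity in this test:
compound 1, `CC(C)COC(=O)Nc1ccc([Se]C#N)cc1`: 73000 nM
compound 2, `C=CCOC(=O)Nc1ccc([Se]C#N)cc1`: 71200 nM

Compound 2 stands side by side with compound 1 on the numbers shown: the step of a 1.0-fold lower number from compound 1 to compound 2 (0.01 log units; within the scatter) lies within the scatter, so on this read-out the two compounds cannot be told apart. Compound 3, `CCOC(=O)Nc1ccc([Se]C#N)cc1`, has not yet been measured in this assay. It differs from compound 2 in one place: methyl in place of vinyl on a saturated chain carbon bound to an oxygen next to a carbonyl group. Among the compounds with values here, the only measured step that bears on this change is the one just named, which exchanged one group for another on the same carbon and left the number where it was. On that basis a further shortening at the same place is expected to leave the number unchanged as well, a 1.0-fold higher number from compound 2 to compound 3 (0.00 log units; within the scatter). The estimate for compound 3 in this assay is therefore 72000 nM, with a range from 40000 nM to 130000 nM.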

Compound 3, concentration lethal to 50% of the cells: 67800 nM
The estimate for compound 3 lay 1.1-fold (0.03 log units) above the measured number; the range from low to high includes it.
By their numbers in this assay, from the lowest: compounds 3, 2 and 1 (each within the scatter of the next).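

Replacing allyl with ethyl gives a 1.1-fold lower number from compound 2 to compound 3 (0.02 log units; within the scatter) in this assay, so losing the double bond of the allyl group leaves no readable mark on this read-out. The wider exchange of isopropyl for methyl on the same carbon gives a 1.1-fold lower number from compound 1 to compound 3 (0.03 log units; within the scatter), so the end groups of compound 1, compound 2 and compound 3 cannot be told apart here, whether they carry a double bond or not. No measurement at hand explains why these exchanges leave the number in place.

From the compounds shown here alone, whether this holds only for small carbon groups stays open, since a much longer chain, an amine or a carboxylic acid at this place could behave differently. Going by these compounds, the shared core is also the same throughout, so what a change elsewhere in the molecule would do remains unknown.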